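The compounds below may be only part of what the source reports. "The series", "measured", "known", "first", "only" and "open" are said of these compounds alone.

Measured so far:
compound 1 `Cc1c(Oc2ccccc2OCCn2ccc(=O)[nH]c2=O)cc(F)c2ccc(C#N)cc12`: > 100000 nM
compound 2 `N#Cc1ccc2c(F)cc(Oc3ccc(F)cc3OCCn3ccc(=O)[nH]c3=O)c(Cl)c2c1`: 28000 nM

In a toxicity assay on MT2 cells (Homo sapiens) for cytotoxicity, read by MTT assay (on this read-out higher numbers stand for lower toxicity in this test and lower numbers for higher toxicity in this test), compound 2 gives 28000 nM, the only number shown in the series. Compound 1 gives > 100000 nM, which is a limit of this assay and not a number. Compound 3 `Cc1c(Oc2ccc(F)cc2OCCn2ccc(=O)[nH]c2=O)cc(F)c2ccc(C#N)cc12` differs from compound 2 by methyl in place of chloro on an aromatic carbon. For the measured compounds named here, no step between two measured compounds is available. The step of a 2.5-fold higher number from compound 2 to compound 3 (0.40 log units; beyond the scatter) is expected to run toward lower toxicity, beyond the scatter, in view of the limit of > 100000 nM in this assay, at which 1 of the 2 values shown sits. Compound 3 is expected to give 70000 nM, within 25000 nM to 200000 nM, and may itself return only a limit.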

Compound 3, half-maximal cytotoxic concentration: > 100000 nM
Compound 3: only a limit was reported; the forecaster's own chance of this, stated with the estimate: 45%; middle value at least 1.4-fold (0.15 log units) from the limit.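

Methyl in place of chloro on an aromatic carbon gives an at least 3.5-fold higher number from compound 2 to compound 3 (0.55 log units; beyond the scatter) in this assay and so ties the only number in the series, that of compound 2, to the chloro group at this position. Compound 3 gives > 100000 nM, which is a limit and not a number. The step therefore fixes only a lower bound on the change because of this ceiling: the limit of > 100000 nM in this assay, at which 2 of the 3 values shown sit.

The step for fluoro in place of hydrogen, from compound 1 to compound 3, cannot be read, since both values are limits. On these data alone, whether a bromo group or an amine at this aromatic carbon would give a number or a limit stays open.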